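Phenyl in place of chloro: compound 1 to compound 3

The source may hold more compounds than are shown below. What is called first, only, known or untested is meant among the compounds shown, and "the series" means these compounds.

For the measured compounds named here, compound 1 `CS(=O)(=O)c1ccc(Cc2n[nH]c(=S)n2/N=C/c2ccc(Cl)cc2)cc1` is the stronger of the two measured members: in a functional assay on HeLa cells (Homo sapiens) for cytotoxicity, read by MTT assay, with a stated time of 48 h, tested at 50 uM (a lower number here means a weaker effect, a higher number a stronger effect of the compound at the concentration tested), compound 1 gives 54%, the highest of the two numbers. Its nearest neighbour, compound 2 `CS(=O)(=O)c1ccc(Cc2n[nH]c(=S)n2/N=C/c2ccccc2F)cc1`, gives 21.9% in this assay, and the change a number 32.1 percentage points lower from compound 1 to compound 2 (beyond the scatter) shows that the aromatic group on the carbon with a double bond to nitrogen is a place where the read-out moves a long way.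

Compound 3 `CS(=O)(=O)c1ccc(Cc2n[nH]c(=S)n2/N=C/c2ccc(-c3ccccc3)cc2)cc1` is not yet measured. It differs from compound 1 by phenyl in place of chloro on an aromatic carbon. Going by the values given here, no measured step makes this same change; the only step in hand, from compound 1 to compound 2, alters the substituent pattern of that same aromatic group and was large, so this position is evidently sensitive, but the direction for phenyl in place of chloro cannot be read from it. The expected step of a number 4 percentage points lower from compound 1 to compound 3 (within the scatter) is therefore set close to none beyond the scatter, with a wide range in either direction. Compound 3 is estimated at 50%, within 22% to 78%.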

Compound 3, a percentage reported as activity, at one concentration (the size of the read-out at that concentration, not a potency): 61.6%
For compound 3 the middle estimate is 11.6 percentage points below the measured one, within the range that was stated.
By their numbers in this assay, from the lowest: compound 2; then compounds 1 and 3 (each within the scatter of the next).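

In this assay the step of a number 7.6 percentage points higher from compound 1 to compound 3 (within the scatter) shows that this aromatic carbon, para to a large group, accepts phenyl, with six heavy atoms and a six-membered aromatic ring, in place of chloro, a single heavy atom, with no change beyond the scatter. The aromatic group on the carbon with a double bond to nitrogen is therefore not sensitive to every change: the large step of a number 32.1 percentage points lower from compound 1 to compound 2 (beyond the scatter) does not carry over to this exchange, and bulk added at this place does not by itself lower the read-out in this pair. Nothing measured on these compounds offers an explanation for this tolerance.

As far as these compounds go, whether the tolerance extends to groups of a different kind at this place, such as an amine, a carboxylic acid or a longer alkyl chain, remains open. Also open, from the compounds shown here alone, is how much of the large step to the 2-fluorophenyl compound belongs to the fluoro group and how much to where it sits, which a 4-fluorophenyl analogue would help to separate.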